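Benzamidomethyl in place of hydroxy in an inactive series

The source may hold more compounds than are shown below. What is called first, only, known or untested is meant among the compounds shown, and "the series" means these compounds.

Compound 1 `NCCCNc1c(C(=O)NCc2ccc(F)cc2)nc(Br)c2cccnc12`: > 20000 nM
Compound 2 `O=C(NCc1ccc(F)cc1)c1nc(Br)c2cccnc2c1NCc1ccc(F)cc1`: > 20000 nM
Compound 3 `O=C(NCc1ccc(F)cc1)c1nc(Br)c2cccnc2c1NCCO`: > 20000 nM

All three compounds were tested in a functional assay on HCT-116 cells (Homo sapiens) for cytotoxicity, read by MTT assay, with a stated time of 72 h (a higher number here means a weaker inhibitor, a lower number a stronger inhibitor), and each value is a limit rather than a number. Compound 3 gives > 20000 nM, which is a limit.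

Compound 4 `O=C(NCCCNc1c(C(=O)NCc2ccc(F)cc2)nc(Br)c2cccnc12)c1ccccc1` carries benzamidomethyl in place of hydroxy on a saturated chain carbon, two bonds along the chain from a nitrogen on an aromatic ring.

For the measured compounds named here, three measured steps bear on this change: a step that the two limits leave unreadable from compound 1 to compound 3, a step that the two limits leave unreadable from compound 1 to compound 2 and a step that the two limits leave unreadable from compound 2 to compound 3. None has a readable size. No step beyond the scatter is therefore expected in this assay, and no direction can be given, since compound 3 sits with the other two at the limit of > 20000 nM in this assay, at which 3 of the 3 values shown sit. The expected step is a step that the limit leaves unreadable from compound 3 to compound 4.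

Compound 4 is estimated at 25000 nM, with an expected range of 8000 nM to 60000 nM.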

Compound 4, half-maximal inhibitory concentration: > 10000 nM
Compound 4: a limit, no number; the forecaster's own chance of this, stated with the estimate: 75%; the middle value does not contradict the limit.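

In this assay compound 4 gives > 10000 nM, which is a limit. The steps from compound 1, compound 2 and compound 3 to compound 4 cannot be read; all four values are limits. The compounds shown leave open whether any of these side chains on the shared core changes cytotoxicity, and in which direction.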